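Reducing the amide and returning to the oxane ring

This account rests on a few compounds, and the source may have more. Where it says the series, first, only, none or still open, it means among the compounds named here.

Compound 2 `COc1ccc(C(=O)NC2CCCC2)cc1-c1[nH]nc2nc(Nc3ccc(F)cc3F)ccc12` gives 34% in a functional assay on the whole organism (strain Wistar) for inhibition, with Rattus norvegicus as the target, at a dose of 25 mg/kg by the oral route; a lower number here means less inhibition, a higher number more inhibition at the dose given (going by the name of the read-out). Compound 1 `COc1ccc(C(=O)NC2CCOCC2)cc1-c1[nH]nc2nc(Nc3ccc(F)cc3F)ccc12` gives 28%, a number within the usual scatter of that of compound 2, as the step of a number 6 percentage points higher from compound 1 to compound 2 (within the scatter) shows. Compound 3 `COc1ccc(CNC2CCOCC2)cc1-c1[nH]nc2nc(Nc3ccc(F)cc3F)ccc12` differs from compound 2 by ((oxan-4-yl)amino)methyl in place of cyclopentylcarbamoyl on an aromatic carbon. Among the measured compounds shown here, no measured step covers this exchange of cyclopentylcarbamoyl for ((oxan-4-yl)amino)methyl; the only step seen swaps the ring alone and stays within the scatter. Compound 3 is therefore expected to give 28%, between 10% and 46%, an expected step of a number 6 percentage points lower from compound 2 to compound 3 (within the scatter) that need not exceed the scatter.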

Compound 3, a percentage reported as inhibition, in the whole organism at one dose (the size of the read-out at that dose, not a potency): 46%
Compound 3: the middle estimate sits 18 percentage points below what was measured; measured number inside the range.
By their numbers in this assay, from the lowest: compounds 1 and 2 (each within the scatter of the next); then compound 3.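

At this position, on an aromatic carbon para to a methoxy group, the linker matters more than the earlier ring swap suggested. Exchanging (oxan-4-yl)carbamoyl for ((oxan-4-yl)amino)methyl keeps the ring but removes the carbonyl, and in this assay gives a number 18 percentage points higher from compound 1 to compound 3 (beyond the scatter), while the exchange for cyclopentylcarbamoyl gives a number 12 percentage points higher from compound 2 to compound 3 (beyond the scatter). No measurement here accounts for this rise.

Still open, from the compounds shown here alone, is whether (cyclopentylamino)methyl would match ((oxan-4-yl)amino)methyl. Going by these compounds, it is also open whether a tertiary amine carrying an added methyl group would keep the gain.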